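From isopropoxy to propylamino on a carbonyl carbon

A few compounds are considered here, and "the series" means these few. Any claim that something is new, unique, unknown or untested is made for them only; others in the source may bear on it.

Measured in a functional assay on cells (Platelet, Homo sapiens) for inhibition (a higher number here means a weaker inhibitor, a lower number a stronger inhibitor), the compounds stand as follows:
- Compound 1 `CCOC(=O)c1ccc(-c2nn(Cc3ccccc3Cl)c3ccccc23)cc1` gives > 10000 nM as a limit
- Compound 2 `CCOC(=O)c1ccc(-c2nn(CC)c3ccccc23)cc1` gives > 10000 nM as a limit
- Compound 3 `CC(C)OC(=O)c1ccc(-c2nn(Cc3ccccc3)c3ccccc23)cc1` gives > 10000 nM as a limit

The set as a whole shows the limit of > 10000 nM in this assay, at which 3 of the 3 values shown sit, and so offers no number to build on. Compound 3 stands at > 10000 nM in this way, a limit and not a number.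

Compound 4 `CCCNC(=O)c1ccc(-c2nn(Cc3ccccc3)c3ccccc23)cc1` differs from compound 3 in one place, with propylamino in place of isopropoxy on a carbonyl carbon as the count of the change: propylamino in place of isopropoxy on a carbonyl carbon.

Among the compounds with values here, only one step has been measured, a step that the two limits leave unreadable from compound 1 to compound 2, and it lies on a saturated chain carbon bound to an aromatic nitrogen, not on the carbonyl carbon. It gives neither a size nor a direction to carry over, so no step beyond the scatter is expected in this assay and another limit is the likeliest outcome.

The estimated step is a step that the limit leaves unreadable from compound 3 to compound 4 on that expectation.

For compound 4 the expected value is 15000 nM with an estimated range from 4000 nM to 60000 nM in this assay as the measurement is awaited.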

Compound 4, half-maximal inhibitory concentration: > 10000 nM
Compound 4: only a limit was reported; the forecaster's own chance of this, stated with the estimate: 75%; the middle value lies beyond the limit too.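

No step can be read from compound 3 to compound 4, because both compounds stand only as limits in this assay: the limit of > 10000 nM in this assay, at which 4 of the 4 values shown sit.

The compounds shown leave open whether any change on the shared core gives a readable number in this assay.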